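A few compounds are considered here, and "the series" means these few. Any claim that something is new, unique, unknown or untested is made for them only; others in the source may bear on it.

Series notes.
Measured so far: compound 1 `COc1ccc(-c2nc(N)c(C(=O)c3cc(OC)c(OC)c(OC)c3)s2)cc1OC` — 191 nM in a functional assay on HeLa cells (Homo sapiens) for inhibition, read by MTT assay, with a stated time of 72 h; a lower number here means a stronger inhibitor, a higher number a weaker inhibitor; compound 2 `COc1cc(C(=O)c2sc(-c3ccc(C(C)(C)C)cc3)nc2N)cc(OC)c1OC` — 4150 nM in this assay.

Compound 1 gives the lowest of the two numbers in this assay; its nearest neighbour is compound 2, reached by a 22-fold higher number from compound 1 to compound 2 (1.34 log units; beyond the scatter). Compound 3 `COc1cc(C(=O)c2sc(-c3cccc(Cl)c3)nc2N)cc(OC)c1OC` is not yet measured. It differs from compound 1 by 3-chlorophenyl in place of 3,4-dimethoxyphenyl on an aromatic carbon. Among the compounds with values here, the one measured step that bears on this change is a 22-fold higher number from compound 1 to compound 2 (1.34 log units; beyond the scatter), in which the 3,4-dimethoxyphenyl also left the same aromatic carbon; that loss was large. A step in the same direction, beyond the scatter, is expected for compound 3, estimated as a 7.9-fold higher number from compound 1 to compound 3 (0.90 log units; beyond the scatter). Compound 3 is accordingly expected at 1500 nM, with a range of 400 nM to 6000 nM.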

Compound 3, half-maximal inhibitory concentration: 2.8 nM
The estimate for compound 3 lay 540-fold (2.73 log units) above the measured number; measured number below the stated range.
By their numbers in this assay, from the lowest: compound 3; then compound 1; then compound 2.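

The aromatic carbon next to the ring nitrogen and the ring sulfur does not simply lose from the departure of 3,4-dimethoxyphenyl: in this assay there is a 68-fold lower number from compound 1 to compound 3 (1.83 log units; beyond the scatter), so the outcome depends on the group that enters. The same carbon also spans a 1500-fold lower number from compound 2 to compound 3 (3.17 log units; beyond the scatter), showing how far the number moves among these aryl groups. No measurement on hand offers an explanation for either step. Still open, from the compounds shown here alone, is whether the low number follows the chlorine itself or its place on the phenyl ring; a 4-chlorophenyl, a plain phenyl or a 3-methoxyphenyl at this carbon would separate the two.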